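Aryl group on the aromatic nitrogen: from methoxy to chloro-trifluoromethyl

The source may hold more compounds than are shown below. What is called first, only, known or untested is meant among the compounds shown, and "the series" means these compounds.

Compound 2 `CCCNC(=O)c1cc(Oc2ccc(NC(=O)c3cc4cccnc4n(-c4ccc(OC)cc4)c3=O)cc2)ccn1` carries a 4-methoxyphenyl group on the aromatic nitrogen of the shared core. Among the measured compounds shown here, in a functional assay on U-87MG ATCC cells for antiproliferative activity against U-87 MG (Homo sapiens), read by MTT assay, with a stated time of 72 h (on this read-out lower numbers stand for stronger inhibition and higher numbers for weaker inhibition), compound 2 gives 8210 nM, the highest of the two numbers so far. For the measured compounds named here, its nearest neighbour, compound 1 `CCCNC(=O)c1cc(Oc2ccc(NC(=O)c3cc4cccnc4n(-c4ccccc4F)c3=O)cc2)ccn1`, gives 2320 nM in this assay, and the step is a 3.5-fold higher number from compound 1 to compound 2 (0.55 log units; beyond the scatter), the only step measured.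

Compound 3 `CCCNC(=O)c1cc(Oc2ccc(NC(=O)c3cc4cccnc4n(-c4ccc(C(F)(F)F)cc4Cl)c3=O)cc2)ccn1` is not yet measured. It differs from compound 2 by 2-chloro-4-(trifluoromethyl)phenyl in place of 4-methoxyphenyl on an aromatic nitrogen. Going by the values given here, the one step that bears on this change is the exchange of 2-fluorophenyl for 4-methoxyphenyl, which gave a 3.5-fold higher number from compound 1 to compound 2 (0.55 log units; beyond the scatter). Among the compounds with values here, compound 3 removes the 4-methoxyphenyl group again and puts a differently substituted phenyl in its place, so a return toward the lower number of compound 1 is expected, though no compound carrying a 2-chloro-4-(trifluoromethyl)phenyl group has been measured and the size of the move is uncertain.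

Compound 3 is expected to give about 2500 nM in this assay, within 700 nM to 9000 nM. This estimate means a 3.3-fold lower number from compound 2 to compound 3 (0.52 log units; beyond the scatter), expected to be a lower number beyond the scatter.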

Compound 3, half-maximal inhibitory concentration: 10900 nM
Beside the measured number, compound 3's estimate is 4.4-fold (0.64 log units) below it, and the stated range ends below it.
By their numbers in this assay, from the lowest: compound 1; then compounds 2 and 3 (each within the scatter of the next).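

In this assay, taking out the 4-methoxyphenyl group does not by itself restore the level of compound 1: the 2-chloro-4-(trifluoromethyl)phenyl group gives a 1.3-fold higher number from compound 2 to compound 3 (0.12 log units; within the scatter), so these two differently substituted aryl groups are not told apart on this read-out. The 2-fluorophenyl group of compound 1 remains separated from this larger group, with a 4.7-fold higher number from compound 1 to compound 3 (0.67 log units; beyond the scatter) as the step, and since both groups carry a halogen, a halogen on this aryl ring does not alone hold the number at the level of compound 1. No measurement at hand gives a reason for either step.

Open, as far as these compounds go, is whether the gap from compound 1 follows the chlorine, the trifluoromethyl or the two together, which a plain 2-chlorophenyl and a plain 4-(trifluoromethyl)phenyl group on the same nitrogen would separate. Also open, from the compounds shown here alone, is where an unsubstituted phenyl, or a cyclopropyl group in place of any aryl ring, would stand against these three compounds.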